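Acylhydrazone series: loss of chloro, antiproliferative read-out

A few compounds are considered here, and "the series" means these few. Any claim that something is new, unique, unknown or untested is made for them only; others in the source may bear on it.

Of the compounds shown here, two have been tested in a functional assay on NCI-H522 cells (Homo sapiens) for antiproliferative activity, read by sulforhodamine B assay, with a stated time of 48 h; on this read-out lower numbers stand for higher toxicity in this test and higher numbers for lower toxicity in this test. Compound 1 `COc1ccc(OC)c(/C=C/c2nnc(Nc3ccc(Cl)cc3)o2)c1` reaches only a limit of the assay there, > 100000 nM. Compound 2 `COc1ccc(OC)c(/C=C/C(=O)N/N=C/c2ccc(Cl)cc2)c1` also reaches only a limit of the assay, > 100000 nM. Where compound 2 stands on the numbers shown is thus at the limit itself, which both values share (the limit of > 100000 nM in this assay, at which 2 of the 2 values shown sit). For the measured compounds named here, no step between measured compounds is available, so no direction of change has been observed.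

Compound 3 `COc1ccc(OC)c(/C=C/C(=O)N/N=C/c2ccccc2)c1` is to be measured in this assay. Its difference from compound 2 is hydrogen in place of chloro on an aromatic carbon. Going by the values given here, with no measured step of any kind to lean on, the step of a number no higher from compound 2 to compound 3 (the limit leaves the size open) is estimated as none beyond the scatter. Compound 3 is therefore expected to give 100000 nM in this assay, with an estimated range from 30000 nM to 300000 nM, most probably reported again only as a limit.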

Compound 3, concentration lethal to 50% of the cells: > 100000 nM
Compound 3 was reported as a limit; the forecaster's own chance of this, stated with the estimate: 80%; the middle value sits exactly at the limit.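

In this assay compound 2 and compound 3 are both reported only as limits, and no step can be read for the change from 4-chlorophenyl to phenyl. Left open is whether these two groups differ at all on this read-out, as every value shown is a limit: the limit of > 100000 nM in this assay, at which 3 of the 3 values shown sit.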